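The compounds below may be only part of what the source reports. "The series", "measured", "known", "first", "only" and "open" are said of these compounds alone.

Three compounds have been tested in a functional assay on NCI-H1975 cells (Homo sapiens) for inhibition, read by MTT assay, with a stated time of 72 h; on this read-out higher numbers stand for weaker inhibition and lower numbers for stronger inhibition:
compound 1, `C=CC(=O)Nc1cccc(NC(=O)CSc2nc(Nc3ccccc3Br)c3ccccc3n2)c1`, giving 19300 nM;
compound 2, `C=CC(=O)Nc1cccc(NC(=O)CSc2nc(Nc3cccc(F)c3)c3ccccc3n2)c1`, giving 2030 nM;
compound 3, `C=CC(=O)Nc1cccc(NC(=O)CSc2nc(Nc3cccc(Cl)c3)c3ccccc3n2)c1`, giving 9460 nM.

Compound 3 thus stands second highest of the three numbers, between compound 1 and compound 2: the swap of the whole aryl group on the nitrogen gave a 2.0-fold lower number from compound 1 to compound 3 (0.31 log units; beyond the scatter), while changing the halogen at one place gave a 4.7-fold higher number from compound 2 to compound 3 (0.67 log units; beyond the scatter).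

Compound 4, `C=CC(=O)Nc1cccc(NC(=O)CSc2nc(Nc3cccc(OC)c3)c3ccccc3n2)c1`, keeps the shared core and differs from compound 3 in a single spot: methoxy in place of chloro on an aromatic carbon. Going by the values given here, the only measured step that touches this same spot is the one from compound 2 to compound 3, where one halogen replaced another and the number rose. Methoxy is neither of those halogens, so this step bears on the question only loosely, and the other two steps concern a different place on the ring. A modest change is expected for compound 4, of uncertain direction, leaning slightly toward a lower number than compound 3, as a 1.6-fold lower number from compound 3 to compound 4 (0.20 log units; within the scatter). Compound 4 is therefore estimated at 6000 nM, with a range from 1500 nM to 25000 nM.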

Compound 4, half-maximal inhibitory concentration: 7940 nM
For compound 4 the middle estimate is 1.3-fold (0.12 log units) below the measured one; the measured number falls inside the stated range.
By their numbers in this assay, from the lowest: compound 2; then compounds 4 and 3 (each within the scatter of the next); then compound 1.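

In this assay the step from chloro to methoxy is a 1.2-fold lower number from compound 3 to compound 4 (0.08 log units; within the scatter) and so cannot be told from repeat-measurement noise, although methoxy, unlike chloro, counts a hydrogen-bond acceptor. Fluoro now stands apart from both groups at this spot: methoxy in place of fluoro gives a 3.9-fold higher number from compound 2 to compound 4 (0.59 log units; beyond the scatter), so the rise seen on leaving fluoro (a 4.7-fold higher number from compound 2 to compound 3 (0.67 log units; beyond the scatter)) is not confined to chloro. The 3-methoxyphenyl group also differs from the 2-bromophenyl group (a 2.4-fold lower number from compound 1 to compound 4 (0.39 log units; beyond the scatter)), as 3-chlorophenyl did.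

No available evidence explains why fluoro differs from chloro and methoxy. Still open, going by these compounds, are how a plain hydrogen, a hydroxy group or an amine at this spot would compare, and whether the 2-bromophenyl result reflects the bromine itself or where it sits.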